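The compounds below may be only part of what the source reports. "The series", "measured", "known", "first", "only" and "open" are said of these compounds alone.

Compound 1 `Cc1ccc2nc(N3CCCc4ccc(F)cc4C3)cc(NC(C)CN)c2c1` gives 25000 nM in an ADME assay on HEp-2 cells (Homo sapiens) for cytotoxicity, read by CCK-8 assay, with a stated time of 5 days; on this read-out higher numbers stand for lower toxicity in this test and lower numbers for higher toxicity in this test.
Compound 2 `Cc1ccc2nc(N3CCCc4ccc(F)cc4C3)cc(NCC3CCCCN3)c2c1` gives 23000 nM in this assay.

Compound 2 holds the lowest of the two numbers in this assay, with compound 1 nearest to it, and the two values lie within the scatter of each other, so neither compound can be set apart from the other on these data. Compound 3 `CC(=O)NCCNc1cc(N2CCCc3ccc(F)cc3C2)nc2ccc(C)cc12` differs from compound 2 in one place: acetamidomethyl in place of piperidin-2-yl on a saturated chain carbon bound to a nitrogen on an aromatic ring. Among the measured compounds shown here, the only measured step that bears on this position is a 1.1-fold lower number from compound 1 to compound 2 (0.04 log units; within the scatter), which likewise exchanged the group carried on the nitrogen on the aromatic ring and stayed within the scatter. For the measured compounds named here, with that single step as the only guide, and no measured change at this position reaching beyond the scatter, no step beyond the scatter is expected in this assay for compound 3. The step from compound 2 to compound 3 is therefore expected to be about a 1.0-fold higher number from compound 2 to compound 3 (0.02 log units; within the scatter). Compound 3 is accordingly estimated at 24000 nM, with a range from 10000 nM to 55000 nM.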

Compound 3, half-maximal cytotoxic concentration: 66000 nM
Compound 3: middle estimate off by 2.8-fold (0.44 log units), on the low side; the whole stated range lies below it.
By their numbers in this assay, from the lowest: compounds 2 and 1 (each within the scatter of the next); then compound 3.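

In this assay, the group on the nitrogen on the aromatic ring proves able to move the read-out: 2-acetamidoethyl in place of (piperidin-2-yl)methyl gives a 2.9-fold higher number from compound 2 to compound 3 (0.46 log units; beyond the scatter), and 2-acetamidoethyl in place of 1-(aminomethyl)ethyl gives a 2.6-fold higher number from compound 1 to compound 3 (0.42 log units; beyond the scatter). The earlier step had stayed within the scatter, whereas both of these go beyond it in the same direction, towards lower toxicity in this test, and 1-(aminomethyl)ethyl carries no ring, so the shift also appears where no ring leaves. Nothing given here accounts for this shift.

Open, on these data alone, is whether the acetyl part of the entering group is what matters, which a plain 2-aminoethyl group on the same nitrogen would help to settle. Also open, as far as these compounds go, is how a longer chain ending in acetamide, or a chain ending in a carboxylic acid, would read in this assay.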